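Cytotoxicity limit and the acetyl step on compound 3

The source may hold more compounds than are shown below. What is called first, only, known or untested is meant among the compounds shown, and "the series" means these compounds.

Measured in an ADME assay on MT4 cells (Homo sapiens) for cytotoxicity; a higher number here means that more compound is tolerated, a lower number that less compound is tolerated:
- compound 1 `O=c1[nH]c2ccc(Cl)cc2n1S(=O)(=O)c1c(F)cccc1F`: 194000 nM
- compound 2 `Cc1cc(C)cc(Cn2c(=S)[nH]c3ccc(Cl)cc32)c1`: 305 nM
- compound 3 `O=c1[nH]c2ccc(Cl)cc2n1Cc1cc(F)cc(F)c1`: > 424000 nM (a limit of the assay, not a number)

Compound 3 gives > 424000 nM, which is a limit of the assay. For the measured compounds named here, it is the only one of the three readings of this kind, as the limit of > 424000 nM in this assay, at which 1 of the 3 values shown sits, records. Less compound is tolerated for compound 2 at 305 nM than for compound 1 at 194000 nM.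

Compound 4 `CC(=O)n1c(=O)n(Cc2cc(F)cc(F)c2)c2cc(Cl)ccc21` is still unmeasured and differs from compound 3 in one place: acetyl in place of hydrogen on an aromatic nitrogen. In words, this is acetyl in place of hydrogen on an aromatic nitrogen.

Going by the values given here, no measured pair shows this change, so the expectation rests on little. A downward step in this assay, of moderate size and beyond the scatter, is expected. Compound 3 shares its carbonyl with the nearest numerical guide, compound 1, which gives 194000 nM. Another limit reading for the new compound would not be surprising.

The expected move, reckoned against a limit and therefore rough, is an at least 2.1-fold lower number from compound 3 to compound 4 (0.32 log units; beyond the scatter). For compound 4 the estimated value is 200000 nM, with an expected range of 40000 nM to 400000 nM.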

Compound 4, half-maximal cytotoxic concentration: 40400 nM
For compound 4 the middle estimate is 5.0-fold (0.69 log units) above the measured one, and the stated range covers the measured number.
By their numbers in this assay, from the lowest: compound 2; then compound 4; then compound 1. At a limit, above all of these: compound 3.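

In this assay, acetyl in place of hydrogen on an aromatic nitrogen gives an at least 10-fold lower number from compound 3 to compound 4 (1.02 log units; beyond the scatter), the only step shown at this position and the first single-place change in the series that can be read. Its full size stays unknown, and the step is only a bound, because compound 3 sits at a limit of the assay: the limit of > 424000 nM in this assay, at which 1 of the 4 values shown sits.

Even so, compound 4 at 40400 nM shows that this ring nitrogen does not tolerate every change without consequence in this assay, since a single acetyl on it is enough to bring the reading down to a measurable number, which the earlier compounds, all differing in more than one place, could not show.

Going by these compounds, whether this step belongs to acetyl in particular or to any group on this nitrogen remains open, and a methyl, a longer chain or a chain ending in an amine at the same place would help to separate the two. Also open, on these data alone, is whether the step carries over to the other substituents on the core, such as the group borne by compound 1 or compound 2.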